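Anilinopyrimidine series: benzylamine to arylamine at the pyrimidine

This account rests on a few compounds, and the source may have more. Where it says the series, first, only, none or still open, it means among the compounds named here.

Working notes on four chloropyrimidine diamines sharing one core. Compound 1 `Cc1ccccc1Nc1nc(Nc2cccnc2)ncc1Cl` gives 38600 nM in a functional assay on Jurkat cells (Homo sapiens) for inhibition, read by CCK-8 assay, with a stated time of 48 h; a higher number here means a weaker inhibitor of growth, a lower number a stronger inhibitor of growth. Compound 2 `Cc1ccccc1Nc1nc(Nc2ccc(N3CCCN(C)CC3)cc2)ncc1Cl` carries a phenyl bearing a methylated diazepane in place of the pyridyl of compound 1. In this assay compound 2 gives 11300 nM. Among the compounds with values here, compound 3 `CN1CCN(c2ccc(Nc3ncc(Cl)c(NCc4ccccc4)n3)nc2)CC1` is the only member with a benzylamine rather than an arylamine on the core, and in this assay compound 3 returns only a limit, > 100000 nM. That places compound 3 at the limit of > 100000 nM in this assay, at which 1 of the 3 values shown sits, so its standing is known only as a bound and not as a number.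

Compound 4 `CC(C)c1cccc(Nc2nc(Nc3ccc(N4CCN(C)CC4)cn3)ncc2Cl)c1` is not yet measured. It differs from compound 3 in one place: 3-isopropylphenyl in place of benzyl on a nitrogen on an aromatic ring. The change returns compound 4 to the arylamine pattern seen in compound 1 and compound 2, both of which give measured numbers in this assay rather than a limit. On that basis a sizeable step toward stronger growth inhibition is expected from compound 3 to compound 4, estimated as an at least 6.6-fold lower number from compound 3 to compound 4 (0.82 log units; beyond the scatter). For compound 4 the value in this assay is expected to be 15000 nM, with a range from 3000 nM to 80000 nM.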

Compound 4, concentration for 50% growth inhibition: 12300 nM
Estimate against measurement, compound 4: 1.2-fold (0.09 log units) above; low and high end bracket the measured number.
By their numbers in this assay, from the lowest: compounds 2 and 4 (each within the scatter of the next); then compound 1. At a limit, above all of these: compound 3.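

Within the data shown here, at the nitrogen on the aromatic ring, 3-isopropylphenyl in place of benzyl gives the first step between compounds that differ in one place: in this assay the change gives an at least 8.1-fold lower number from compound 3 to compound 4 (0.91 log units; beyond the scatter). Compound 4 thus returns a measured number, so this position clearly bears on growth inhibition of Jurkat cells. The step is only a bound, with its true size unknown, because compound 3 stands at a limit: the limit of > 100000 nM in this assay, at which 1 of the 4 values shown sits.

From the compounds shown here alone, whether the change owes its effect to the aryl group sitting directly on that nitrogen or to the isopropyl group stays open. A plain phenyl on that nitrogen would separate the two, and a methoxy group or an amine in place of the isopropyl would test what that group contributes.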